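Nitro substitution next to ethoxy on a biphenyl ester series

The source may report more compounds than this note shows. Statements on the series, on what has been measured and on what is new or still open speak of the compounds shown alone.

Measured compounds:
- compound 1 `CCOC(=O)c1cccc(-c2ccc(OCC)cc2)c1`: 87%
- compound 2 `CCOC(=O)c1cccc(-c2ccc(N(C)C)cc2)c1`: 87%

In an assay on COS-7 cells for inhibition of patatin-like phospholipase domain-containing protein 2 (Mus musculus), tested at 200 uM (on this read-out lower numbers stand for less inhibition and higher numbers for more inhibition at the one concentration tested (going by the name of the read-out)), compound 1 gives 87%. Compound 2 gives 87%, and the step of no change at the digits printed from compound 1 to compound 2 (within the scatter) shows that dimethylamino in place of ethoxy on an aromatic carbon leaves the read-out unchanged. For the measured compounds named here, compound 1 therefore stands level with compound 2, the only other measured compound.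

Compound 3 `CCOC(=O)c1cccc(-c2ccc(OCC)c([N+](=O)[O-])c2)c1` is not yet measured. It differs from compound 1 by nitro in place of hydrogen on an aromatic carbon. Going by the values given here, no measured step involves a nitro group, so nothing bears directly on this change. Among the compounds with values here, the only measured step, from compound 1 to compound 2, was within the scatter, and the shared core is the same. With no evidence either way, the expected step of a number 7 percentage points lower from compound 1 to compound 3 (within the scatter) is none beyond the scatter, with a wide range. Compound 3 is estimated at 80% in this assay, between 55% and 95%.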

Compound 3, a percentage reported as inhibition, at one concentration (the size of the read-out at that concentration, not a potency): 44%
The estimate for compound 3 lay 36 percentage points above the measured number; the whole stated range lies above it.
By their numbers in this assay, from the lowest: compound 3; then compounds 1 and 2 (each within the scatter of the next).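

In this assay, the aromatic carbon ortho to an ethoxy group is not indifferent to substitution: nitro in place of hydrogen gives a number 43 percentage points lower from compound 1 to compound 3 (beyond the scatter). The earlier step, no change at the digits printed from compound 1 to compound 2 (within the scatter), replaced the ethoxy group itself and said nothing about this carbon. The series now holds a change beyond the scatter, and it comes from adding a group to the ring with the ethoxy group kept, while no data bear on what lies behind the drop.

As far as these compounds go, whether the drop belongs to nitro itself or would also follow an amine, a methyl group or a chlorine atom on the same carbon remains open. Also open, from the compounds shown here alone, is whether nitro gives a step of similar size on the core of compound 2, with dimethylamino in place of ethoxy.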